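This account rests on a few compounds, and the source may have more. Where it says the series, first, only, none or still open, it means among the compounds named here.

Compound 1 `CC(O)(CSc1ccc(C(F)(F)F)cc1)C(=O)Nc1ccc(S(F)(F)(F)(F)F)cc1`: 24800 nM
Compound 2 `CC(O)(CSc1cccc(C(F)(F)F)c1)C(=O)Nc1ccc(S(F)(F)(F)(F)F)cc1`: 18800 nM
Compound 3 `CC(O)(CSc1ccccc1C(F)(F)F)C(=O)Nc1ccc(S(F)(F)(F)(F)F)cc1`: 21000 nM

All three values come from a functional assay on VCaP cells (Homo sapiens) for antiproliferative activity, read by propidium iodide staining, with a stated time of 96 h; a higher number here means a weaker inhibitor, a lower number a stronger inhibitor. Compound 3 cannot be told apart from the other two: the data show a 1.2-fold lower number from compound 1 to compound 3 (0.07 log units; within the scatter) and a 1.1-fold higher number from compound 2 to compound 3 (0.05 log units; within the scatter). Compound 4 `CC(O)(CSc1ccccc1OC(F)(F)F)C(=O)Nc1ccc(S(F)(F)(F)(F)F)cc1` carries one change: trifluoromethoxy in place of trifluoromethyl on an aromatic carbon, ortho to a large group. Within the data shown here, no measured step makes this exchange. The closest evidence is the shift of the trifluoromethyl group around the ring, which gave a 1.3-fold lower number from compound 1 to compound 2 (0.12 log units; within the scatter) along with the two steps above. A step no larger than the scatter is therefore expected in this assay, with no direction favoured. The estimated step is a 1.1-fold lower number from compound 3 to compound 4 (0.02 log units; within the scatter). Compound 4 is expected at 20000 nM, with an estimated range of 10000 nM to 36000 nM.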

Compound 4, half-maximal inhibitory concentration: 10100 nM
Compound 4: middle estimate off by 2.0-fold (0.30 log units), on the high side; measured number inside the range.
By their numbers in this assay, from the lowest: compounds 4, 2, 3 and 1 (each within the scatter of the next, the first and the last beyond it).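

In this assay, trifluoromethoxy in place of trifluoromethyl on this aromatic carbon, ortho to a large group, gives a 2.1-fold lower number from compound 3 to compound 4 (0.32 log units; beyond the scatter) and is the only step among these compounds beyond the scatter. Moving trifluoromethyl around the ring gave nothing of that size, as a 1.3-fold lower number from compound 1 to compound 2 (0.12 log units; within the scatter) and the other such steps stay within the scatter. No measured property accounts for this step. On these data alone, whether trifluoromethoxy would give a like step from compound 1 or compound 2 stays open. So does how a methoxy group or a chlorine atom would read at this position.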